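Methyl on the core of compound 2: half-life notes

A few compounds are considered here, and "the series" means these few. Any claim that something is new, unique, unknown or untested is made for them only; others in the source may bear on it.

Measured so far in an ADME assay on microsomes from liver (Homo sapiens) for metabolic stability, read by LC-MS, using NADPH, tested at 3 uM; on this read-out lower numbers stand for a shorter-lived compound and higher numbers for a longer-lived compound:
- compound 1 `O=C(O)CC(c1ccccc1)c1c(-c2ccccc2)[nH]c2ccccc12` gives 1.05 h
- compound 2 `O=C(C(c1ccccc1)c1c(-c2ccccc2)[nH]c2ccccc12)C(F)(F)F` gives 0.852 h
- compound 3 `OC(C(c1ccccc1)c1c(-c2ccccc2)[nH]c2ccccc12)C(F)(F)F` gives 0.657 h

Compound 2 stands second highest of the three numbers in this assay, and both of its steps to the other two lie within the scatter: a 1.2-fold lower number from compound 1 to compound 2 (0.09 log units; within the scatter) and a 1.3-fold lower number from compound 2 to compound 3 (0.11 log units; within the scatter). The remaining step, a 1.6-fold lower number from compound 1 to compound 3 (0.20 log units; within the scatter), is also within the scatter, so the three measured compounds are not separated by this assay.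

Compound 4 `Cc1ccc2c(C(C(=O)C(F)(F)F)c3ccccc3)c(-c3ccccc3)[nH]c2c1` is the next compound to be measured. Its difference from compound 2 is methyl in place of hydrogen on an aromatic carbon. Among the compounds with values here, all three measured steps concern the group on the saturated chain carbon bound to two aromatic carbons; none of them touches a six-membered aromatic ring of carbon only, so no measured step bears directly on this change. What the series shows is that three different groups at the chain carbon left this assay within the scatter, which gives no basis to expect a large step here either. The step is therefore expected to stay within the scatter, without a clear direction.

Compound 4 is expected to give 0.8 h in this assay, with a range from 0.4 h to 1.6 h. This estimate means an expected 1.1-fold lower number from compound 2 to compound 4 (0.03 log units; within the scatter).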

Compound 4, half-life: 4.45 h
For compound 4 the middle estimate is 5.6-fold (0.75 log units) below the measured one, outside the stated range (above it).
By their numbers in this assay, from the lowest: compounds 3, 2 and 1 (each within the scatter of the next); then compound 4.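

In this assay, within the data shown here, methyl in place of hydrogen on an aromatic carbon of a six-membered aromatic ring of carbon only, part of a fused system of two rings, gives a 5.2-fold higher number from compound 2 to compound 4 (0.72 log units; beyond the scatter) and so is the first step to pass the scatter. The steps among compounds 1, 2 and 3 all changed the group on the saturated chain carbon and stayed within the scatter, whereas this change on the shared core, which adds only 1 heavy atom, shows that the half-life responds to a substitution at this aromatic carbon, at least with the (trifluoromethyl)carbonyl group in place on the chain carbon. Nothing at hand gives a reason for the size or direction of this step.

The compounds shown leave open whether the step belongs to this aromatic carbon or would also follow methyl on other carbons of that ring, and whether a fluorine, a methoxy group or a longer chain such as ethyl would act as methyl does here. They also leave open whether the same methyl would shift the half-life with carboxymethyl or 2,2,2-trifluoro-1-hydroxyethyl on the chain carbon.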